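The source may hold more compounds than are shown below. What is called first, only, known or untested is meant among the compounds shown, and "the series" means these compounds.

Measured so far in a functional assay on HeLa cells (Homo sapiens) for inhibition, read by CCK-8 assay, with a stated time of 48 h; a lower number here means a stronger inhibitor, a higher number a weaker inhibitor:
compound 1 `COc1ccc(-c2cc3nccc(-c4cc(OC)c(OC)c(OC)c4)n3n2)cc1N` — 283 nM
compound 2 `COc1cc(-c2ccnc3cc(-c4ccc(Cl)cc4)nn23)cc(OC)c1OC` — 1490 nM
compound 3 `COc1cc(-c2ccnc3cc(-c4ccc(-c5cnn(C)c5)cc4)nn23)cc(OC)c1OC` — 1830 nM

Among these three numbers compound 2 stands second highest. Its nearest neighbour is compound 3, which lies within the scatter of it; the step of a 1.2-fold higher number from compound 2 to compound 3 (0.09 log units; within the scatter) is too small to count as a change. Going by the values given here, the only step beyond the scatter in the set is a 5.3-fold higher number from compound 1 to compound 2 (0.72 log units; beyond the scatter), which shows that the group on the six-membered aromatic ring of carbon only does move this assay when it is changed substantially.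

Compound 4 `COc1cc(-c2ccnc3cc(-c4ccc(C(F)(F)F)cc4)nn23)cc(OC)c1OC` differs from compound 2 in one place: trifluoromethyl in place of chloro on an aromatic carbon. Among the compounds with values here, no measured pair tests trifluoromethyl against chloro, so the step from compound 2 to compound 4 has no direct precedent. The nearest guide is the exchange of chloro for another group at the same carbon, which gave only a 1.2-fold higher number from compound 2 to compound 3 (0.09 log units; within the scatter). On that basis the expected step of a 1.2-fold higher number from compound 2 to compound 4 (0.08 log units; within the scatter) is small, within the scatter or at most slightly toward a higher number. Compound 4 is therefore expected to give about 1800 nM, with a likely range from 700 nM to 4500 nM.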

Compound 4, half-maximal inhibitory concentration: 1840 nM
For compound 4 the middle estimate is 1.0-fold (0.01 log units) below the measured one, within the range that was stated.
By their numbers in this assay, from the lowest: compound 1; then compounds 2, 3 and 4 (each within the scatter of the next).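

In this assay the carbon para to a large group now carries a third group, and trifluoromethyl gives a 1.2-fold higher number from compound 2 to compound 4 (0.09 log units; within the scatter) and a 1.0-fold higher number from compound 3 to compound 4 (0.00 log units; within the scatter) so that chloro, 1-methyl-1H-pyrazol-4-yl and trifluoromethyl cannot be told apart in this set. Replacing 3-amino-4-methoxyphenyl with 4-(trifluoromethyl)phenyl gives a 6.5-fold higher number from compound 1 to compound 4 (0.81 log units; beyond the scatter) and adds a second step beyond the scatter, so both such steps now start from compound 1. No measurement at hand offers an explanation for either observation.

Open, going by these compounds, is whether the amine or the methoxy on the phenyl of compound 1 accounts for that separation, or whether both are needed. Also open, on these data alone, is whether a hydroxyl or a carboxylic acid in place of trifluoromethyl would stay within the scatter of compound 4.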